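From 4-hydroxyphenyl to anilino on a shared core

The compounds below may be only part of what the source reports. "The series", "measured", "known", "first", "only" and "open" are said of these compounds alone.

Values measured in a functional assay on HepG2 cells (Homo sapiens) for cytotoxicity, read by sulforhodamine B assay, with a stated time of 24 h (on this read-out lower numbers stand for stronger inhibition and higher numbers for weaker inhibition), are as follows
Compound 1 `N=c1oc2ccccc2cc1C(=O)N/N=C1\C(=O)Nc2ccc(S(=O)(=O)N3CCOCC3)cc21` gives 7820 nM
Compound 2 `O=C1Nc2ccc(S(=O)(=O)N3CCOCC3)cc2/C1=N/c1ccc(O)cc1` gives 10400 nM
Compound 3 `O=C1Nc2ccc(S(=O)(=O)N3CCOCC3)cc2/C1=N/NC(=O)c1ccccc1` gives 18100 nM

These numbers lie close together. Compound 2 (10400 nM) stands within the usual scatter of both other compounds, so it cannot be ranked against either. Compound 4 `O=C1Nc2ccc(S(=O)(=O)N3CCOCC3)cc2/C1=N/Nc1ccccc1` is not yet measured. It carries anilino in place of 4-hydroxyphenyl on a double-bonded nitrogen.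

The closest guide is a change at that same place, where benzamido replaced 4-hydroxyphenyl and gave a 1.7-fold higher number from compound 2 to compound 3 (0.24 log units; within the scatter) as the result. Among the compounds with values here, the only step beyond the scatter is modest, a 2.3-fold higher number from compound 1 to compound 3 (0.36 log units; beyond the scatter), and it lies at a carbonyl carbon, so it bears less directly on this change. Three compounds make a thin basis, but nothing here points to a large move. The expected result in this assay is no step beyond the scatter, with a 1.2-fold higher number from compound 2 to compound 4 (0.06 log units; within the scatter) as the estimated size. For compound 4 the estimated value is 12000 nM (expected range 5500 nM to 25000 nM).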

Compound 4, half-maximal inhibitory concentration: 15600 nM
Estimate against measurement, compound 4: 1.3-fold (0.11 log units) below; measured number inside the range.
By their numbers in this assay, from the lowest: compounds 1, 2, 4 and 3 (each within the scatter of the next, the first and the last beyond it).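

In this assay, exchanging 4-hydroxyphenyl for anilino on the double-bonded nitrogen, where a nitrogen takes the place of an oxygen in a group of equal size, does not separate the two compounds (a 1.5-fold higher number from compound 2 to compound 4 (0.18 log units; within the scatter)). Phenyl in place of benzoyl on the amine nitrogen, which removes the carbonyl, does not separate two compounds either (a 1.2-fold lower number from compound 3 to compound 4 (0.06 log units; within the scatter)). Anilino therefore joins 4-hydroxyphenyl and benzamido as a third group at this place, and compounds 2, 3 and 4 cannot be told apart in this read-out.

As far as these compounds go, whether a carboxylic acid or an amine on the anilino ring, or a longer chain in place of that ring, would move the number beyond the scatter remains open. Nothing available here gives a reason for these values.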